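Series notes: pyridinone amides, lipophilicity at neutral pH

A few compounds are considered here, and "the series" means these few. Any claim that something is new, unique, unknown or untested is made for them only; others in the source may bear on it.

Measured so far in a physicochemical assay for lipophilicity, at pH 7.4; on this read-out lower numbers stand for lower lipophilicity and higher numbers for higher lipophilicity:
compound 1 `CNC(=O)c1cc(C(=O)NC2CCC2)cn(Cc2cccc(NC)c2)c1=O` gives 3.6;
compound 2 `CNC(=O)c1cc(C(=O)NC2CCC2)cn(Cc2cccnc2)c1=O` gives 1.8;
compound 3 `CNC(=O)c1cccn(Cc2ccccc2)c1=O` gives 3.

Compound 3 stands second highest of the three; compound 1 lies higher, beyond the scatter, and compound 2 lies lower, beyond the scatter. Among the compounds with values here, the one single-point step is a number 1.80 log units lower from compound 1 to compound 2 (beyond the scatter), a large drop.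

Compound 4 `CNC(=O)c1cc(C(=O)NCCC(C)C)cn(Cc2ccccc2)c1=O` is not yet measured. It differs from compound 3 in one place: isopentylcarbamoyl in place of hydrogen on an aromatic carbon. Within the data shown here, the step from compound 1 to compound 2 concerns the group on the saturated chain carbon and does not bear on this change; no measured pair carries an isopentylcarbamoyl in place of hydrogen. For compound 4 in this assay the expectation is a modest rise, a number 0.60 log units higher from compound 3 to compound 4 (beyond the scatter), with an estimate of 3.6 and a range from 3 to 4.2.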

Compound 4, distribution coefficient: 4.8
For compound 4 the middle estimate is 1.20 log units below the measured one; the measured number lies above the stated range.
By their numbers in this assay, from the lowest: compound 2; then compound 3; then compound 1; then compound 4.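

In this assay, within the data shown here, isopentylcarbamoyl in place of hydrogen on the aromatic carbon two atoms from the ring nitrogen gives a number 1.80 log units higher from compound 3 to compound 4 (beyond the scatter), the first read on a change at this position. The size of this rise matches the fall in a number 1.80 log units lower from compound 1 to compound 2 (beyond the scatter), so a change at this aromatic carbon can shift the read-out as far as a change on the saturated chain carbon. No supporting measurement bears on why the number rises here. From the compounds shown here alone, it remains open how much of the step belongs to the chain and how much to the amide; a carboxylic acid or a shorter chain such as ethylcarbamoyl at this carbon would separate the two.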